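A few compounds are considered here, and "the series" means these few. Any claim that something is new, unique, unknown or untested is made for them only; others in the source may bear on it.

Three compounds share one core and differ only in a single group on an aromatic carbon at one end of the molecule. In a functional assay on C6 cells (Rattus norvegicus) for cytotoxicity, read by MTT assay, with a stated time of 24 h, tested at 6 ug/mL (on this read-out higher numbers stand for a weaker effect at the one concentration tested and lower numbers for a stronger effect), compound 1 `Cc1ccc(-c2cs/c(=N/NC(=O)CSc3nnnn3-c3ccccc3)n2-c2ccccc2)cc1` gives 66.8% at the one concentration tested. In this assay compound 2 `O=C(CSc1nnnn1-c1ccccc1)N/N=c1/scc(-c2ccc(F)cc2)n1-c1ccccc1` gives 74.9% at that same concentration. In this assay compound 3 `O=C(CSc1nnnn1-c1ccccc1)N/N=c1/scc(-c2ccccc2)n1-c1ccccc1` gives 52.1% under the same conditions. Among these three numbers compound 2 holds the highest, though the step of a number 8.1 percentage points higher from compound 1 to compound 2 (within the scatter) lies within the scatter, while the steps of a number 22.8 percentage points lower from compound 2 to compound 3 (beyond the scatter) and a number 14.7 percentage points lower from compound 1 to compound 3 (beyond the scatter) lie beyond it and are modest in size.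

Compound 4 `O=C(CSc1ncccn1)N/N=c1/scc(-c2ccc(F)cc2)n1-c1ccccc1` has not yet been measured. Among the measured compounds shown here, it differs from compound 2 at the other end of the molecule, with pyrimidin-2-yl in place of 1-phenyl-1H-tetrazol-5-yl on a sulfur as the only change. None of the three measured steps touches this part of the structure; all of them concern the group on the aromatic carbon at the far end. For the measured compounds named here, there is therefore no measured step that bears directly on the change, and the expectation has to rest on the reading of compound 2 alone, with a wide range.

Compound 4 is expected to give 72% in this assay with a range from 50% to 92% around it. The expected step of a number 2.9 percentage points lower from compound 2 to compound 4 (within the scatter) is thus none beyond the scatter.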

Compound 4, a percentage reported as activity, at one concentration (the size of the read-out at that concentration, not a potency): 84%
The estimate for compound 4 lay 12 percentage points below the measured number; measured number inside the range.
By their numbers in this assay, from the lowest: compound 3; then compounds 1, 2 and 4 (each within the scatter of the next, the first and the last beyond it).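

In this assay, replacing 1-phenyl-1H-tetrazol-5-yl on the sulfur with pyrimidin-2-yl gives a number 9.1 percentage points higher from compound 2 to compound 4 (within the scatter), so the two compounds cannot be told apart on this read-out. Among the compounds shown here, this is the first look at the sulfur end of the molecule, since all the earlier steps concerned the group on the aromatic carbon at the far end. It shows that, with fluoro on that carbon, a group of two rings can give way to one of a single ring and fewer heavy atoms without a step beyond the scatter, though no evidence here says what lies behind this result.

Still open, as far as these compounds go, is whether pyrimidin-2-yl would behave the same way with hydrogen on the aromatic carbon, as in compound 3 at 52.1%, or with methyl, as in compound 1 at 66.8%, since those are the groups that gave steps beyond the scatter. Also open, from the compounds shown here alone, is what the sulfur end tolerates without any aromatic ring, for example a plain ethyl chain or a short chain ending in a carboxylic acid.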